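The source may report more compounds than this note shows. Statements on the series, on what has been measured and on what is new or still open speak of the compounds shown alone.

Working notes on the series. Of the compounds shown here, two have been measured in a functional assay on the whole organism for antagonist activity, with Rattus norvegicus as the target; on this read-out lower numbers stand for an effect already at smaller amounts and higher numbers for an effect only at larger amounts of compound. Compound 1 `CN(C)c1ncnc2c1ncn2C1CC1` gives 9 mg/kg in this assay. Compound 2 `c1nc(NC2CC2)c2ncn(CC3CCC3)c2n1` gives 10 mg/kg in this assay. Compound 2 thus stands within the scatter of compound 1; the two numbers cannot be told apart, and neither compound can be called more or less potent than the other on this evidence.

The next compound, compound 3 `c1nc(NC2CC2)c2ncn(C3CC3)c2n1`, is the cyclopropyl in place of cyclobutylmethyl on an aromatic nitrogen analogue of compound 2: cyclopropyl in place of cyclobutylmethyl on an aromatic nitrogen. Within the data shown here, no pair among the measured compounds differs in this one place, so there is no measured step to lean on. Compound 1 already carries a cyclopropyl on the same ring nitrogen and compound 1 gives 9 mg/kg, which does not suggest that this substituent moves the read-out far. The step from compound 2 to compound 3 is therefore expected to be small, no change at the digits printed from compound 2 to compound 3 (within the scatter), in no particular direction beyond the scatter. Compound 3 is estimated at 10 mg/kg in this assay, with a range from 4 mg/kg to 25 mg/kg.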

Compound 3, dose for half-maximal effect: 4.5 mg/kg
Estimate against measurement, compound 3: 2.2-fold (0.35 log units) above; low and high end bracket the measured number.
By their numbers in this assay, from the lowest: compounds 3, 1 and 2 (each within the scatter of the next, the first and the last beyond it).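

Among these compounds, on the aromatic nitrogen, cyclopropyl in place of cyclobutylmethyl gives a 2.2-fold lower number from compound 2 to compound 3 (0.35 log units; beyond the scatter) in this assay and is the first step to pass beyond the scatter, so this position does respond to the group it carries, if only modestly. With cyclopropyl held on that nitrogen, cyclopropylamino in place of dimethylamino on an aromatic carbon gives a 2.0-fold lower number from compound 1 to compound 3 (0.30 log units; within the scatter) and so shows no clear effect of that exchange. No available evidence bears on the origin of the step at the aromatic nitrogen.

From the compounds shown here alone, a single step between two ring groups gives no trend, so it remains open whether an open chain such as ethyl or a larger ring such as cyclopentyl on that nitrogen would go the same way. Going by these compounds, it also remains open how a cyclic amine such as morpholine would read on the aromatic carbon.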